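This account rests on a few compounds, and the source may have more. Where it says the series, first, only, none or still open, it means among the compounds named here.

Measured so far:
- compound 1 `COc1cc(/C=C/C(=O)/C=C/c2cccs2)ccc1OCc1cn(CCCCCOc2cc(=O)oc3ccccc23)nn1`: 30%
- compound 2 `COc1ccccc1/C=C/C(=O)/C=C/c1ccc(OCc2cn(CCCCCOc3cc(=O)oc4ccccc34)nn2)c(OC)c1`: 30%

In a functional assay on COLO 205 cells (Homo sapiens) for inhibition, read by sulforhodamine B assay, with a stated time of 48 h, tested at 50 uM (on this read-out lower numbers stand for less inhibition of growth and higher numbers for more inhibition of growth at the one concentration tested), compound 2 gives 30%, level with compound 1 at 30%. Within the data shown here, no measured compound in this small set stands apart from the other.

The next compound to consider is compound 3 `COc1cc(/C=C/C(=O)/C=C/c2ccccc2)ccc1OCc1cn(CCCCCOc2cc(=O)oc3ccccc23)nn1`. It differs from compound 2 by hydrogen in place of methoxy on an aromatic carbon, ortho to a large group, so that 2-methoxyphenyl becomes phenyl.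

Among the measured compounds shown here, only one measured step bears on this change: no change at the digits printed from compound 1 to compound 2 (within the scatter). That step replaced thiophen-2-yl with 2-methoxyphenyl, the same group that is altered in compound 3, and it left this assay within the scatter. For the measured compounds named here, this is thin evidence, since it is a single step and no phenyl compound has been measured. Still, nothing in the data points to a shift in either direction.

The expected result is no change at the digits printed from compound 2 to compound 3 (within the scatter), with no step beyond the scatter anticipated. For compound 3 the estimated value is 30%, with an expected range from 20% to 41%.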

Compound 3, percent growth inhibition at one concentration: 22%
Beside the measured number, compound 3's estimate is 8 percentage points above it; the measured number falls inside the stated range.
By their numbers in this assay, from the lowest: compounds 3, 1 and 2 (each within the scatter of the next).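

In this assay, taking methoxy off the aromatic carbon ortho to a large group gives a number 8 percentage points lower from compound 2 to compound 3 (within the scatter), so this position tolerates either methoxy or hydrogen without a step beyond the scatter. Phenyl itself can now be set against thiophen-2-yl, with a number 8 percentage points lower from compound 1 to compound 3 (within the scatter), and together with no change at the digits printed from compound 1 to compound 2 (within the scatter) this shows that thiophen-2-yl, 2-methoxyphenyl and phenyl are not separated at this end of the chain. No accompanying measurement bears on these results.

The compounds shown leave open whether a different kind of group on the six-membered aromatic ring, such as an amine or a carboxylic acid, would produce a step beyond the scatter, as all the changes so far are confined to methoxy, hydrogen and the exchange of thiophen-2-yl for a phenyl ring. They also leave open whether a longer chain in the part common to all three compounds would move the number, and how these compounds compare at any other concentration.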